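Swapping the aryl group on the aminothiazole of a chalcone

This account rests on a few compounds, and the source may have more. Where it says the series, first, only, none or still open, it means among the compounds named here.

Compound 1 (`COc1cc(/C=C/C(=O)c2sc(Nc3ccc(Cl)cc3)nc2C)cc(OC)c1OC`) was tested in a functional assay on Bel-7402 cells (Homo sapiens) for cytotoxicity, read by MTT assay; a lower number here means a stronger inhibitor, a higher number a weaker inhibitor. In this assay compound 1 gives > 25000 nM, which is a limit of the assay and not a number. Compound 2 (`Cc1ccccc1Nc1nc(C)c(C(=O)/C=C/c2ccccc2Cl)s1`) gives > 25000 nM in this assay, again a limit rather than a number. Compound 1 therefore stands at the limit of > 25000 nM in this assay, at which 2 of the 2 values shown sit, with no measured number to set it apart from compound 2.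

Compound 3 (`COc1cc(/C=C/C(=O)c2sc(Nc3cccc(C)c3)nc2C)cc(OC)c1OC`) has not yet been measured in this assay. It differs from compound 1 in one place: 3-methylphenyl in place of 4-chlorophenyl on a nitrogen on an aromatic ring. Going by the values given here, no step between two measured compounds with this change is available, so the expectation rests on the two limits alone. The step from compound 1 to compound 3 is estimated as a step that the limit leaves unreadable from compound 1 to compound 3, that is, nothing beyond the scatter. Compound 3 is accordingly expected to give about 30000 nM, within 10000 nM to 100000 nM, most likely again as a limit.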

Compound 3, half-maximal inhibitory concentration: > 25000 nM
Compound 3: a limit, no number; the forecaster's own chance of this, stated with the estimate: 75%; the middle value is on the limit's open side.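

Going by these compounds alone, compound 3 gives only a limit and not a number, as compound 1 does, so no step between compound 1 and compound 3 can be read: the limit of > 25000 nM in this assay, at which 3 of the 3 values shown sit. The compounds shown leave open whether 3-methylphenyl and 4-chlorophenyl differ in effect on these cells at all.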